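A few compounds are considered here, and "the series" means these few. Any claim that something is new, unique, unknown or untested is made for them only; others in the source may bear on it.

Measured so far in an assay on HEK293 cells for inhibition of Voltage-dependent T-type calcium channel subunit alpha-1G (Homo sapiens), read by patch clamp; a lower number here means a stronger inhibitor, a higher number a weaker inhibitor:

Compound 1 `O=C(CCCN1CCN(c2ccccc2)CC1)Nc1ccc(Cl)cc1`: compound 1 gives 4470 nM.
Compound 2 `COc1cccc(N2CCN(CCCC(=O)Nc3ccc(Cl)cc3)CC2)c1`: compound 2 gives 2780 nM.
Compound 3 `O=C(CCCN1CCN(c2ccccc2)CC1)Nc1ccc(Cl)cc1Cl`: compound 3 gives 4210 nM.

Compound 3 sits alongside compound 1 in this assay, the step of a 1.1-fold lower number from compound 1 to compound 3 (0.03 log units; within the scatter) being no larger than repeat measurements. Among the compounds with values here, compound 3 also lies close to compound 2, whose number differs from that of compound 3 by less than the scatter; no single-point step links those two. None of the three measured numbers separates from the others beyond the scatter.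

Compound 4 `COc1cccc(N2CCN(CCCC(=O)Nc3ccc(Cl)cc3Cl)CC2)c1` is compound 3 with the change (methoxy in place of hydrogen on an aromatic carbon). Within the data shown here, the one measured step of the same kind is a 1.6-fold lower number from compound 1 to compound 2 (0.21 log units; within the scatter), which stayed within the scatter. On that basis the step of a 1.5-fold lower number from compound 3 to compound 4 (0.18 log units; within the scatter) in this assay is expected to be of similar size, a slightly lower number at most, not a change beyond the scatter. Compound 4 is estimated at 2800 nM, with a range from 1400 nM to 5600 nM.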

Compound 4, half-maximal inhibitory concentration: 3810 nM
The estimate for compound 4 lay 1.4-fold (0.13 log units) below the measured number, and the stated range covers the measured number.
By their numbers in this assay, from the lowest: compounds 2, 4, 3 and 1 (each within the scatter of the next).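

Phenyl to 3-methoxyphenyl now has a second reading in this assay, on the core that carries the added chloro: a 1.1-fold lower number from compound 3 to compound 4 (0.04 log units; within the scatter). Set against the first reading, the methoxy step stays within the scatter on both cores, and the two readings agree: the same change on two cores in this assay, a 1.6-fold lower number (0.21 log units; within the scatter) from compound 1 to compound 2 and a 1.1-fold lower number (0.04 log units; within the scatter) from compound 3 to compound 4, 1.5-fold (0.16 log units) apart, within the scatter of two such steps. The chloro change also gains a second reading, a 1.4-fold higher number from compound 2 to compound 4 (0.14 log units; within the scatter), which likewise stays within the scatter, so that change too shows no step beyond the scatter on either core: the same change on two cores in this assay, a 1.1-fold lower number (0.03 log units; within the scatter) from compound 1 to compound 3 and a 1.4-fold higher number (0.14 log units; within the scatter) from compound 2 to compound 4, 1.5-fold (0.16 log units) apart, within the scatter of two such steps.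

The four compounds vary only by hydrogen, methoxy and chloro, and none of their numbers separates from the others beyond the scatter, so the series does not yet show any change that moves this number. On these data alone, whether an amine, a carboxylic acid or a longer chain in place of the methoxy would give a step beyond the scatter remains open.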